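Adding an Isopropyl Group to a Weak Carbamate Inhibitor

The source may report more compounds than this note shows. Statements on the series, on what has been measured and on what is new or still open speak of the compounds shown alone.

Compound 1, `C#CCN1CCC(OC(=O)Nc2ccccc2)CC1`, gives > 100000 nM in an assay on BTI-TN-5B1-4 cells for inhibition of Amine oxidase [flavin-containing] B (Homo sapiens), read by fluorescence and Amplex Red, using microsomes, with a stated time of 15 min (a lower number here means a stronger inhibitor, a higher number a weaker inhibitor), which is a limit of the assay and not a number.
Compound 2, `O=C(Nc1ccccc1)OC1CCN(Cc2ccccc2)CC1`, gives > 100000 nM in this assay, again a limit and not a number.
Compound 3, `O=C(Nc1ccccc1)OC1CCCN(Cc2ccccc2)C1`, gives 33300 nM in this assay.

Among the measured compounds shown here, compound 3 thus stands as the only compound with a measured number; the two other values are limits. For the measured compounds named here, the single measured step, a step that the two limits leave unreadable from compound 1 to compound 2, cannot be read because both of its values sit at the limit of > 100000 nM in this assay, at which 2 of the 3 values shown sit. Going by the values given here, no measured step touches the part of the molecule changed here.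

Compound 4, `CC(C)c1ccc(NC(=O)OC2CCCN(Cc3ccccc3)C2)cc1`, differs from compound 3 by isopropyl in place of hydrogen on an aromatic carbon. Among the compounds with values here, since no measured step bears on this change, there is no basis for expecting movement in either direction, and the step of a 1.1-fold lower number from compound 3 to compound 4 (0.05 log units; within the scatter) is expected to lie within the usual scatter, with a wide range around it. Compound 4 is therefore estimated at 30000 nM, between 6000 nM and 120000 nM.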

Compound 4, half-maximal inhibitory concentration: 29300 nM
The estimate for compound 4 lay 1.0-fold (0.01 log units) above the measured number; measured number inside the range.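

Among the compounds shown here, the step of a 1.1-fold lower number from compound 3 to compound 4 (0.06 log units; within the scatter) is the first readable measurement of a change at this position, an aromatic carbon of the six-membered aromatic ring, para to a large group. In this assay, adding isopropyl and its 3 heavy atoms there leaves compound 3 and compound 4 indistinguishable, so this position tolerates the group without any readable gain or loss in inhibition. Nothing measured here explains why the numbers stay level.

On these data alone, whether an amine, a carboxylic acid or a longer chain at this position would give a number beyond the scatter from compound 3 remains open. A single substitution also cannot show whether a group placed elsewhere on this aromatic ring would behave the same way as isopropyl does here.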